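Thiophen-3-yl in place of furan-3-yl on the shared core

The source may report more compounds than this note shows. Statements on the series, on what has been measured and on what is new or still open speak of the compounds shown alone.

In a functional assay on HeLa S3 cells (Homo sapiens) for antiproliferative activity, read by XTT assay, with a stated time of 72 h (on this read-out higher numbers stand for weaker inhibition and lower numbers for stronger inhibition), compound 1 (`COc1ncnc2c1c(-c1cc3ccccc3o1)cn2[C@@H]1O[C@H](CO)[C@@H](O)[C@H]1O`) gives 9240 nM and compound 2 (`Nc1nc2c(c(-c3ccoc3)cn2[C@@H]2O[C@H](CO)[C@@H](O)[C@H]2O)c(=O)[nH]1`) gives 10700 nM as its number, and these two values lie within the scatter of each other. Compound 3 (`Nc1nc2c(c(-c3ccsc3)cn2[C@@H]2O[C@H](CO)[C@@H](O)[C@H]2O)c(=O)[nH]1`) carries thiophen-3-yl in place of furan-3-yl on an aromatic carbon and otherwise matches compound 2. Going by the values given here, no measured pair shows this change. In this assay no step beyond the scatter is expected in either direction, and the estimated step is a 1.2-fold lower number from compound 2 to compound 3 (0.08 log units; within the scatter) for this exchange. Compound 3 is expected at 9000 nM with an estimated range from 3000 nM to 27000 nM for the measurement.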

Compound 3, half-maximal inhibitory concentration: > 20000 nM
Compound 3: only a limit was reported; the forecaster's own chance of this, stated with the estimate: 20%; at least 2.2-fold (0.34 log units) between middle value and limit.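

In this assay compound 3 gives > 20000 nM, which is a limit of the assay and not a number. Going by these compounds alone, this gives the first readable exchange at this position, an at least 1.8-fold higher number from compound 2 to compound 3 (0.27 log units; that floor lies within the scatter), so thiophen-3-yl in place of furan-3-yl shows no sign of a lower number here. The full size of this step cannot be read from the data, and the floor is all that is available: the limit of > 20000 nM in this assay, at which 1 of the 3 values shown sits.

As far as these compounds go, what an amine or a longer alkyl chain would give on this aromatic carbon remains open. So does whether the same exchange would behave alike on the core of compound 1.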